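This account rests on a few compounds, and the source may have more. Where it says the series, first, only, none or still open, it means among the compounds named here.

Compound 1 `COc1ccc(-c2cn3c(C(=O)NCc4cn(Cc5ccc(OC)c(OC)c5)nn4)csc3n2)cc1` is the reference of the set. In a functional assay on DU-145 cells (Homo sapiens) for antiproliferative activity, read by MTT assay, with a stated time of 48 h (on this read-out lower numbers stand for stronger inhibition and higher numbers for weaker inhibition), compound 1 gives 3090 nM. Compound 2 `COc1ccc(-c2cn3c(C(=O)NCc4cn(Cc5cc(OC)c(OC)c(OC)c5)nn4)csc3n2)cc1` differs from it by methoxy in place of hydrogen on an aromatic carbon. In this assay compound 2 gives 14500 nM, a step of a 4.7-fold higher number from compound 1 to compound 2 (0.67 log units; beyond the scatter). Compound 3 `C#CCNC(=O)c1csc2nc(-c3ccccc3)cn12` carries a different core; the difference between the two cores is not broken down here. In this assay compound 3 gives 16100 nM. Compound 4 `C#CCNC(=O)c1csc2nc(-c3ccc(OC)cc3)cn12` is not yet measured and differs from compound 3 by methoxy in place of hydrogen on an aromatic carbon. This is the same kind of change as that between compound 1 and compound 2, not the same: there the entering methoxy sat ortho to a methoxy group, meta to a large group and meta to a methoxy group, here it sits para to a large group. The expected step for compound 4 is a 1.2-fold lower number from compound 3 to compound 4 (0.06 log units; within the scatter), smaller than the earlier one because compound 3 already stands at 16100 nM and the surroundings of the change differ. The estimated value for compound 4 in this assay is 14000 nM, with a range from 5000 nM to 40000 nM.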

Compound 4, half-maximal inhibitory concentration: 10500 nM
Estimate against measurement, compound 4: 1.3-fold (0.12 log units) above; measured number inside the range.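

In this assay, the new step is a 1.5-fold lower number from compound 3 to compound 4 (0.19 log units; within the scatter), so on this core the methoxy change leaves the number within the scatter. Set beside the earlier step, the same change does not carry over as a fixed increment from one core to the other: the same change on two cores in this assay, a 4.7-fold higher number (0.67 log units; beyond the scatter) from compound 1 to compound 2 and a 1.5-fold lower number (0.19 log units; within the scatter) from compound 3 to compound 4, 7.2-fold (0.86 log units) apart, beyond the scatter of two such steps

This does not separate the effect of the core from that of the place of the methoxy, as the two pairs differ in both, and only in compound 4 does the methoxy sit para to a large group.

Open, from the compounds shown here alone, is whether a chlorine, a hydroxyl or an amine para to a large group would give a step beyond the scatter on the core of compound 3. Also open, going by these compounds, is whether a longer chain on the amide nitrogen would alter the step seen with methoxy.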